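Methylcarbamoyl to ethylcarbamoyl on the shared core

The source may hold more compounds than are shown below. What is called first, only, known or untested is meant among the compounds shown, and "the series" means these compounds.

Compound 1 `CNC(=O)c1cc(Oc2ccc(NC(=O)c3cc4cccnc4n(-c4ccccc4)c3=O)cc2)ccn1` is the reference point of this pair. For the measured compounds named here, in a functional assay on A549 cells (Homo sapiens) for antiproliferative activity, read by MTT assay, with a stated time of 72 h (a lower number here means a stronger inhibitor, a higher number a weaker inhibitor), compound 1 gives 200 nM, the higher of the two numbers measured so far. Going by the values given here, its nearest neighbour is compound 2 `CNC(=O)c1cc(Oc2ccc(NC(=O)c3cc4cccnc4n(-c4ccc(F)cc4)c3=O)cc2)ccn1`, which in this assay gives 110 nM; the only measured step, a 1.8-fold lower number from compound 1 to compound 2 (0.26 log units; within the scatter), stays within the scatter, so the two numbers are not separated.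

Compound 3 `CCNC(=O)c1cc(Oc2ccc(NC(=O)c3cc4cccnc4n(-c4ccccc4)c3=O)cc2)ccn1` has not yet been measured. Compared with compound 1 it carries methyl in place of hydrogen on a saturated chain carbon bound to an amide-type nitrogen.

Among the compounds with values here, no measured step touches this place. Within the data shown here, the one step on record, a 1.8-fold lower number from compound 1 to compound 2 (0.26 log units; within the scatter), concerns a fluoro substituent on an aromatic carbon, a different part of the molecule, and it stayed within the scatter. Among the measured compounds shown here, nothing among the measured compounds therefore points to a change beyond the scatter for a one-carbon extension of the amide chain, and the expected step is no change at the digits printed from compound 1 to compound 3 (within the scatter).

For compound 3 the estimated value in this assay is 200 nM, with a range from 80 nM to 500 nM.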

Compound 3, half-maximal inhibitory concentration: 160 nM
The estimate for compound 3 lay 1.3-fold (0.10 log units) above the measured number; the range from low to high includes it.
By their numbers in this assay, from the lowest: compounds 2, 3 and 1 (each within the scatter of the next).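

In this assay, for the compounds shown here, the methyl added on the saturated chain carbon bound to an amide-type nitrogen gives a 1.3-fold lower number from compound 1 to compound 3 (0.10 log units; within the scatter); this is the first reading at this position, which the fluoro step left untouched. The shared core therefore carries ethylcarbamoyl as well as methylcarbamoyl with no separation between the two numbers, so this one-carbon extension leaves compound 3 indistinguishable from compound 1 at 200 nM in this assay. No measurement on hand bears on the reason for this reading.

Still open, on these data alone, is how far the position goes on behaving this way: a longer chain such as propyl, a branched isopropyl group, a cyclopropyl ring or a chain ending in an amine could either stay within the scatter of compound 1 or move clearly beyond it. Also open, as far as these compounds go, is what ethylcarbamoyl does in a molecule that also has the fluoro substituent on the aromatic carbon, since the two changes have so far been read only one at a time on the shared core.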